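This account rests on a few compounds, and the source may have more. Where it says the series, first, only, none or still open, it means among the compounds named here.

Compound 1 `CCCCCCCOc1ccc(CCC(N)(CO)CO)cc1`, compound 2 `CCCCCCCOc1ccc(CCC(N)(CO)CCO)cc1` and compound 3 `CCCCCCCCc1ccc(CCC(N)(CO)CCO)cc1` share a cluster of an amine and hydroxy-bearing chains on a saturated carbon, attached through a two-carbon link to a substituted benzene ring. In a functional assay on the whole organism (spleen, spleen) with Rattus norvegicus as the target (on this read-out lower numbers stand for an effect already at smaller amounts and higher numbers for an effect only at larger amounts of compound), compound 1 gives 0.014 mg/kg, compound 2 gives 0.055 mg/kg and compound 3 gives 0.12 mg/kg. The change hydroxymethyl in place of hydroxy on a saturated chain carbon, two bonds along the chain from an amine nitrogen produced a 3.9-fold higher number from compound 1 to compound 2 (0.59 log units; beyond the scatter). Compound 4 `CCCCCCCCc1ccc(CCC(N)(CO)CCCO)cc1` is not yet measured; the difference between the core of compound 3 and that of compound 1 is not broken down here. The change to compound 4 is hydroxymethyl in place of hydroxy on a saturated chain carbon, three bonds along the chain from an amine nitrogen, the same kind of change as before, but now three bonds along the chain from the amine nitrogen rather than two. On that basis the step is expected to be a 3.3-fold higher number from compound 3 to compound 4 (0.52 log units; beyond the scatter), because compound 1 to compound 2 showed a 3.9-fold higher number from compound 1 to compound 2 (0.59 log units; beyond the scatter). Compound 4 is therefore estimated at 0.4 mg/kg, within 0.15 mg/kg to 1.2 mg/kg.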

Compound 4, dose for 50% inhibition: 0.021 mg/kg
The estimate for compound 4 lay 19-fold (1.28 log units) above the measured number; the measured number lies below the stated range.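

Hydroxymethyl in place of hydroxy gave a 5.7-fold lower number from compound 3 to compound 4 (0.76 log units; beyond the scatter) in this assay, so the step seen on the core of compound 1 did not carry over to the core of compound 3, and the two steps run in opposite directions: the same change on two cores in this assay, a 3.9-fold higher number (0.59 log units; beyond the scatter) from compound 1 to compound 2 and a 5.7-fold lower number (0.76 log units; beyond the scatter) from compound 3 to compound 4, 22-fold (1.35 log units) apart, beyond the scatter of two such steps

In this series, then, the size and direction of this change on one core cannot simply be transferred to another. The comparison does not show what drives the reversal, since the two steps differ both in their core and in the place of the change, two bonds or three bonds along the chain from the amine nitrogen.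

On these data alone, it remains open how the 3-hydroxypropyl chain would behave on the core of compound 1. A longer hydroxy-bearing chain, or a carboxylic acid in place of the hydroxy, is also left open.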